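A series held at its limit: chloro to methoxy

The source may report more compounds than this note shows. Statements on the series, on what has been measured and on what is new or still open speak of the compounds shown alone.

Measured in a physicochemical assay for solubility, at pH 7.9; a higher number here means a more soluble compound, a lower number a less soluble compound:
Compound 1 `O=c1c(-c2ccccc2)cn(C2CC2)c2cc(N3CCNCC3)c(F)cc12` gives > 400000 nM, a limit.
Compound 2 `O=c1c(-c2ccc(F)cc2)cn(C2CC2)c2cc(N3CCNCC3)c(F)cc12` gives > 400000 nM, a limit.
Compound 3 `O=c1c(-c2cccc(Cl)c2)cn(C2CC2)c2cc(N3CCNCC3)c(F)cc12` gives > 400000 nM, a limit.

Compound 3 has no exact number to stand on. Compound 3 shows > 400000 nM, which is a limit of the assay and not a number. The other two compounds are limits as well, so the three cannot be ranked.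

Compound 4 `COc1cccc(-c2cn(C3CC3)c3cc(N4CCNCC4)c(F)cc3c2=O)c1` differs from compound 3 by a single change: methoxy in place of chloro on an aromatic carbon. In words, this is methoxy in place of chloro on an aromatic carbon, so 3-chlorophenyl becomes 3-methoxyphenyl.

Going by the values given here, three measured steps bear on this change. The closest is the swap of one substituted phenyl for another, a step that the two limits leave unreadable from compound 2 to compound 3. Adding a substituent gives a step that the two limits leave unreadable from compound 1 to compound 2 and a step that the two limits leave unreadable from compound 1 to compound 3. None of these has a readable size. With compound 1, compound 2 and compound 3 all at the limit of > 400000 nM in this assay, at which 3 of the 3 values shown sit, no step beyond the scatter is expected in this assay, and no direction can be argued. The expected step is a number no higher from compound 3 to compound 4 (the limit leaves the size open). Compound 4 is expected at 400000 nM, with an estimated range from 150000 nM to 800000 nM.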

Compound 4, solubility: > 400000 nM
Compound 4: no number, only a limit (the forecaster's own chance of this, stated with the estimate: 80%); the middle value sits exactly at the limit.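

Compound 4 gives > 400000 nM, a limit of the assay and not a number. No step from compound 1, compound 2 or compound 3 to compound 4 can be read in this assay, because all four compounds stop at the same limit: the limit of > 400000 nM in this assay, at which 4 of the 4 values shown sit.

Going by these compounds, whether these four compounds differ in solubility at all, and by how much, stays open.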